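Fluoro to Chloro: Expecting Compound 3 in this Assay

The source may report more compounds than this note shows. Statements on the series, on what has been measured and on what is new or still open speak of the compounds shown alone.

Compound 1, `CC(=O)Nc1ccc(S(=O)(=O)NNc2ccc(Cl)cc2)cc1`: 155 nM
Compound 2, `CC(=O)Nc1ccc(S(=O)(=O)NNc2ccc(Cl)c(F)c2)cc1`: 194 nM

In an assay for inhibition of Indoleamine 2,3-dioxygenase 1 (Homo sapiens), read by spectrophotometry, with stated times of 1 h and 4 h (on this read-out higher numbers stand for weaker inhibition and lower numbers for stronger inhibition), compound 1 gives 155 nM and compound 2 gives 194 nM. Among the compounds with values here, compound 2 carries the higher of the two numbers, but the only measured step, a 1.3-fold higher number from compound 1 to compound 2 (0.10 log units; within the scatter), stays within the scatter, so the two compounds cannot be told apart on these numbers.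

Compound 3, `CC(=O)Nc1ccc(S(=O)(=O)NNc2ccc(Cl)c(Cl)c2)cc1`, differs from compound 2 in one place: chloro in place of fluoro on an aromatic carbon. Within the data shown here, no measured pair exchanges fluoro for chloro, so the only guide is the step from compound 1 to compound 2, which put fluoro onto this same carbon and changed nothing beyond the scatter. A further one-atom swap at that carbon is therefore expected to move the number little, with no direction to favour; the expected step is a 1.0-fold lower number from compound 2 to compound 3 (0.01 log units; within the scatter).

For compound 3 the estimate in this assay is 190 nM, with a range from 95 nM to 380 nM.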

Compound 3, half-maximal inhibitory concentration: 247 nM
Estimate against measurement, compound 3: 1.3-fold (0.11 log units) below, and the stated range covers the measured number.
By their numbers in this assay, from the lowest: compounds 1, 2 and 3 (each within the scatter of the next).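

In this assay chloro in place of fluoro on this aromatic carbon gives a 1.3-fold higher number from compound 2 to compound 3 (0.10 log units; within the scatter) and chloro in place of hydrogen on the same carbon gives a 1.6-fold higher number from compound 1 to compound 3 (0.20 log units; within the scatter) as the second comparison. Until now only fluoro had been compared with hydrogen here; with chloro added, hydrogen, fluoro and chloro at this place, ortho to a chloro group, cannot be told apart on these numbers. No measurement shown here accounts for this flat result.

Open, on these data alone, is whether this carbon stays as unresponsive with quite different groups, such as a methoxy group, an amine or a carboxylic acid. As far as these compounds go, all three compounds also keep the rest of the core unchanged, so it remains open whether the same holds once the neighbouring chloro group is replaced by hydrogen.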